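The source may report more compounds than this note shows. Statements on the series, on what has been measured and on what is new or still open speak of the compounds shown alone.

Measured so far:
- compound 1 `Cc1cc(C)cc(S(=O)(=O)c2c(C(=O)NC(C)C(=O)NCc3ccccc3F)[nH]c3ccc(Cl)cc23)c1`: 23300 nM
- compound 2 `Cc1cc(C)cc(S(=O)(=O)c2c(C(=O)NCc3ccc4nc(N)[nH]c4c3)[nH]c3ccc(Cl)cc23)c1`: 5890 nM
- compound 3 `Cc1cc(C)cc(S(=O)(=O)c2c(C(=O)NC(C)C(=O)NCc3ccncc3)[nH]c3ccc(Cl)cc23)c1`: 19500 nM

In an ADME assay on MT4 cells (Homo sapiens) for cytotoxicity, read by MTT assay (a higher number here means that more compound is tolerated, a lower number that less compound is tolerated), compound 3 gives 19500 nM, the second highest of the three numbers. Its nearest neighbour is compound 1, reached by a 1.2-fold lower number from compound 1 to compound 3 (0.08 log units; within the scatter), a step within the scatter. The furthest is compound 2: a 3.3-fold higher number from compound 2 to compound 3 (0.52 log units; beyond the scatter) is a modest step beyond the scatter.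

Compound 4 `Cc1cc(C)cc(S(=O)(=O)c2c(C(=O)NC(C)c3ccco3)[nH]c3ccc(Cl)cc23)c1` is not yet measured. It differs from compound 3 by furan-2-yl in place of ((pyridin-4-yl)methyl)carbamoyl on a saturated chain carbon bound to an amide-type nitrogen and a saturated chain carbon. The step cuts the chain short: the terminal carbamoyl with its ring is removed and a smaller aromatic ring takes its place on the same saturated chain carbon.

Neither measured step is a close match. The step from compound 1 to compound 3 exchanges one ring for another at the end of an intact chain and produced no change beyond the scatter; the step from compound 2 to compound 3 exchanges the whole group on the amide-type nitrogen and gave only a modest shift. With no shortening of the chain among the measured compounds, no direction can be read off; a step within or close to the scatter is the working expectation, a 1.3-fold lower number from compound 3 to compound 4 (0.11 log units; within the scatter). Compound 4 is therefore estimated at 15000 nM in this assay, with a range from 5000 nM to 40000 nM.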

Compound 4, half-maximal cytotoxic concentration: > 54700 nM
Compound 4 was reported as a limit (the forecaster's own chance of this, stated with the estimate: 10%); middle value at least 3.6-fold (0.56 log units) away from the limit.
By their numbers in this assay, from the lowest: compound 2; then compounds 3 and 1 (each within the scatter of the next). At a limit, above all of these: compound 4.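

In this assay compound 4 is reported only as a limit, not as a number: the limit of > 54700 nM in this assay, at which 1 of the 4 values shown sits.

Putting furan-2-yl in place of the ((pyridin-4-yl)methyl)carbamoyl on the saturated chain carbon gives a step beyond the scatter, an at least 2.8-fold higher number from compound 3 to compound 4 (0.44 log units; beyond the scatter), and the same holds for the replacement of (2-fluorobenzyl)carbamoyl, an at least 2.3-fold higher number from compound 1 to compound 4 (0.37 log units; beyond the scatter). The exchange of one ring for another at the end of the intact chain, by contrast, stayed within the scatter, a 1.2-fold lower number from compound 1 to compound 3 (0.08 log units; within the scatter), so among these compounds the change that removes the carbamoyl is the one that moves the number at this position, and the widest listed gap to compound 4 is an at least 9.2-fold higher number from compound 2 to compound 4 (0.96 log units; beyond the scatter).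

As far as these compounds go, the loss of the carbamoyl and the arrival of furan-2-yl come together in a single step, so their separate contributions stay open, and a phenyl or a carboxylic acid on the same saturated chain carbon would be needed to pull them apart. From the compounds shown here alone, with compound 4 standing at a limit, the full size of all three steps also remains unknown, and each can be read only as a minimum.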